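Aryl change on the pyridazinone nitrogen: compound 3 to compound 4

A few compounds are considered here, and "the series" means these few. Any claim that something is new, unique, unknown or untested is made for them only; others in the source may bear on it.

Measured compounds in a functional assay on HT-29 cells (Homo sapiens) for inhibition, read by MTT assay, with a stated time of 72 h; on this read-out higher numbers stand for weaker inhibition and lower numbers for stronger inhibition:
compound 1 `COc1cc2c(Oc3ccc(NC(=O)c4nn(-c5ccccc5C)c(=O)cc4C)cc3F)ccnc2cc1OCCCN1CCCC1`, 1400 nM
compound 2 `COc1cc2c(Oc3ccc(NC(=O)c4nn(-c5ccccc5OC(F)(F)F)c(=O)cc4C)cc3F)ccnc2cc1OCCCN1CCCC1`, 180 nM
compound 3 `COc1ccc(-n2nc(C(=O)Nc3ccc(Oc4ccnc5cc(OCCCN6CCCC6)c(OC)cc45)c(F)c3)c(C)cc2=O)cc1`, 3300 nM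

Compound 3 gives the highest of the three numbers in this assay; compound 1 stands nearest, compound 2 furthest. Compound 4 `COc1cc2c(Oc3ccc(NC(=O)c4nn(-c5ccc(F)c(F)c5)c(=O)cc4C)cc3F)ccnc2cc1OCCCN1CCCC1` differs from compound 3 only in this place: 3,4-difluorophenyl in place of 4-methoxyphenyl on an aromatic nitrogen.

For the measured compounds named here, two measured steps touch the same position. The step of a 2.4-fold higher number from compound 1 to compound 3 (0.37 log units; beyond the scatter) and the step of an 18-fold higher number from compound 2 to compound 3 (1.26 log units; beyond the scatter) both show 4-methoxyphenyl giving higher numbers than the two other aryl groups tested. Compound 4 carries a third aryl group, 3,4-difluorophenyl, which appears nowhere among the measured compounds, so nothing measured tells directly how it compares. Given that 4-methoxyphenyl stands worst of the three aryl groups, a modest lowering is expected, but with wide uncertainty.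

For compound 4 an expected value of 1500 nM in this assay is estimated, within 400 nM to 5000 nM, which would mean an expected step of a 2.2-fold lower number from compound 3 to compound 4 (0.34 log units; beyond the scatter).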

Compound 4, half-maximal inhibitory concentration: 150 nM
For compound 4 the middle estimate is 10-fold (1.00 log units) above the measured one, outside the stated range (below it).
By their numbers in this assay, from the lowest: compounds 4 and 2 (each within the scatter of the next); then compound 1; then compound 3.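

In this assay, 3,4-difluorophenyl in place of 4-methoxyphenyl on the aromatic nitrogen gives a 22-fold lower number from compound 3 to compound 4 (1.34 log units; beyond the scatter), so this position can shift the read-out strongly without a 2-(trifluoromethoxy)phenyl group. Compound 2 is no longer alone at the low end: a 1.2-fold lower number from compound 2 to compound 4 (0.08 log units; within the scatter) leaves the two level, while a 9.3-fold lower number from compound 1 to compound 4 (0.97 log units; beyond the scatter) separates 3,4-difluorophenyl from 2-methylphenyl. Among these four compounds, the two aryl groups carrying fluorine give lower numbers than the two without it, and no compound shown goes against this.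

Nothing at hand explains these differences. Open, going by these compounds, is whether one fluorine suffices, as in 4-fluorophenyl or 3-fluorophenyl, and whether 4-(trifluoromethoxy)phenyl or unsubstituted phenyl would fall with compound 2 and compound 4 or with compound 1 and compound 3.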